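A few compounds are considered here, and "the series" means these few. Any claim that something is new, unique, unknown or untested is made for them only; others in the source may bear on it.

Measured compounds:
Compound 1, `Cc1ccc(-c2cc3ncn([C@H]4CCN(C(=O)N(C)[C@H]5CCN(C6CCOCC6)C5)C4)c(=O)c3s2)cc1`, in an assay on isolated protein for binding affinity to melanin-concentrating hormone receptor 1 (Homo sapiens) (a lower number here means a stronger inhibitor, a higher number a weaker inhibitor), gives 14 nM.
Compound 2, `Cc1ccc(-c2cc3ncn([C@H]4CCN(C(=O)N(C)[C@H]5CCN(C6CCOCC6)C5)C4)c(=O)c3s2)c(C)c1`, in this assay gives 70 nM.
Compound 3, `CN(C(=O)N1CC[C@H](n2cnc3cc(-c4ccc(OC(F)(F)F)cc4)sc3c2=O)C1)[C@H]1CCN(C2CCOCC2)C1`, in this assay gives 18 nM.

Compound 3 sits second highest of the three numbers; its nearest neighbour is compound 1, and the two lie within the scatter of each other, while compound 2 stands clearly higher, as a 3.9-fold lower number from compound 2 to compound 3 (0.59 log units; beyond the scatter) shows.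

The next compound is compound 4, `CCOc1ccc(-c2cc3ncn([C@H]4CCN(C(=O)N(C)[C@H]5CCN(C6CCOCC6)C5)C4)c(=O)c3s2)c(Cl)c1`. It differs from compound 3 as follows: 2-chloro-4-ethoxyphenyl in place of 4-(trifluoromethoxy)phenyl on an aromatic carbon.

Among the compounds with values here, two measured steps bear on this change. Within the data shown here, the first, a 1.3-fold higher number from compound 1 to compound 3 (0.11 log units; within the scatter), shows that swapping the single group on the phenyl ring between methyl and trifluoromethoxy made no difference beyond the scatter. The second, a 5.0-fold higher number from compound 1 to compound 2 (0.70 log units; beyond the scatter), shows that adding a methyl to the phenyl ring, so that it carries two groups instead of one, cost a modest amount of binding. Among the measured compounds shown here, compound 4 likewise carries two groups on its phenyl ring, a chloro and an ethoxy, though no measured compound holds either of these. A modest weakening is therefore expected, with the step of a 2.5-fold higher number from compound 3 to compound 4 (0.40 log units; beyond the scatter). Compound 4 is estimated at 45 nM, within a range from 15 nM to 140 nM.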

Compound 4, inhibition constant: 14 nM
Compound 4: the middle estimate sits 3.2-fold (0.51 log units) above what was measured; the whole stated range lies above it.
By their numbers in this assay, from the lowest: compounds 1, 4 and 3 (each within the scatter of the next); then compound 2.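

In this assay, carrying two groups on the phenyl ring at this position, next to the ring sulfur, does not by itself cost binding: with 2-chloro-4-ethoxyphenyl in place of 4-(trifluoromethoxy)phenyl there is a 1.3-fold lower number from compound 3 to compound 4 (0.11 log units; within the scatter), and against 4-methylphenyl there is no change at the digits printed from compound 1 to compound 4 (within the scatter). So compounds 1, 3 and 4 form one group despite quite different groups on the phenyl ring, and compound 2 alone stands apart, with a 5.0-fold lower number from compound 2 to compound 4 (0.70 log units; beyond the scatter), which means the loss seen with 2,4-dimethylphenyl belongs to those particular groups and not simply to there being two of them. No measurement on these compounds accounts for this difference between the two disubstituted rings.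

Compound 4 differs from compound 2 in both groups at once, so the shown compounds cannot tell whether the chloro or the ethoxy is what separates it from compound 2, and a phenyl ring carrying only one of the two would be needed to pull them apart. As far as these compounds go, it also remains open how far this tolerance extends, for instance to a phenyl ring carrying a longer chain such as butoxy, an amine or a carboxylic acid.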